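The compounds below may be only part of what the source reports. "The series", "measured", "known", "first", "only" and "open" are said of these compounds alone.

In an assay for inhibition of Thromboxane-A synthase (Homo sapiens), using microsomes (on this read-out higher numbers stand for weaker inhibition and lower numbers for stronger inhibition), compound 1 `COc1ccccc1OC(C)(C)C1OCC(C/C=C\CCC(=O)O)C(c2cccnc2)O1` gives 60 nM, the highest of the two numbers here; its nearest neighbour, compound 2 `COc1ccc(OC(C)(C)C2OCC(C/C=C\CCC(=O)O)C(c3cccnc3)O2)c([N+](=O)[O-])c1`, gives 37 nM, and a 1.6-fold lower number from compound 1 to compound 2 (0.21 log units; within the scatter). Compound 3 `Cc1ccc(SC(C)(C)C2OCC(C/C=C\CCC(=O)O)C(c3cccnc3)O2)c([N+](=O)[O-])c1` has not yet been measured in this assay. It differs from compound 1 by a group of 11 heavy atoms (7 carbon, 1 nitrogen, 2 oxygen, 1 sulfur; one six-membered aromatic ring of carbon only) in place of a group of 9 heavy atoms (7 carbon, 2 oxygen; one six-membered aromatic ring of carbon only), on a saturated chain carbon bound to two saturated chain carbons and a saturated ring carbon. Among the compounds with values here, the only measured step touching this place, a 1.6-fold lower number from compound 1 to compound 2 (0.21 log units; within the scatter), stayed within the scatter, so no step beyond the scatter is expected in this assay for this larger exchange either. Compound 3 is therefore estimated at 45 nM, with a range from 15 nM to 150 nM, which is expected to mean a 1.3-fold lower number from compound 1 to compound 3 (0.12 log units; within the scatter).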

Compound 3, half-maximal inhibitory concentration: 30 nM
Compound 3: middle estimate off by 1.5-fold (0.18 log units), on the high side; measured number inside the range.
By their numbers in this assay, from the lowest: compounds 3, 2 and 1 (each within the scatter of the next).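

The place on the saturated chain carbon takes a larger group than either earlier compound carried there, one that also holds sulfur and nitrogen, with a 2.0-fold lower number from compound 1 to compound 3 (0.30 log units; within the scatter). Even this wider exchange of the 2-methoxyphenoxy group therefore leaves the number within the scatter. Nothing at hand explains this outcome.

Within the data shown here, the single exchange in compound 3 cannot show what the sulfur contributes apart from the rest of the entering group. Going by these compounds, it also remains open whether a group without an aromatic ring, such as an amine or a carboxylic acid, would be accepted at this place.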